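The source may hold more compounds than are shown below. What is called first, only, known or untested is meant among the compounds shown, and "the series" means these compounds.

In a functional assay on MGC-803 cells (Homo sapiens) for inhibition, read by sulforhodamine B assay (on this read-out lower numbers stand for stronger inhibition and higher numbers for weaker inhibition), compound 2 `Cc1ccc(NC2=CC(=O)c3c(nc4n3[C@H]3OC[C@@H](O)[C@H]3OC4)C2=O)cc1C` gives 1050 nM, the lowest of the two numbers in hand, though compound 1 `CCCc1ccc(NC2=CC(=O)c3nc4n(c3C2=O)[C@H]2OC[C@@H](O)[C@H]2OC4)cc1` with 1560 nM sits within the scatter of it. Compound 3 `CCCN(CCC)C1=CC(=O)c2nc3n(c2C1=O)[C@H]1OC[C@@H](O)[C@H]1OC3` reaches only the assay limit of > 16000 nM. Compound 4 `O=C1C(NC2CCCCC2)=CC(=O)c2c1nc1n2[C@H]2OC[C@@H](O)[C@H]2OC1` has not yet been measured; its difference from compound 2 is cyclohexyl in place of 3,4-dimethylphenyl on an amine nitrogen. Compound 3 also carries a non-aromatic group on the amine nitrogen, and its limit, (the limit of > 16000 nM in this assay, at which 1 of the 3 values shown sits), suggests that losing the aromatic ring weakens inhibition. The step is therefore expected to be a 5.2-fold higher number from compound 2 to compound 4 (0.72 log units; beyond the scatter), a rise in the number beyond the scatter. For compound 4 the estimate is 5500 nM, with a range from 1500 nM to 16000 nM.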

Compound 4, half-maximal inhibitory concentration: > 8000 nM
Compound 4: only a limit was reported; the forecaster's own chance of this, stated with the estimate: 30%; middle value at least 1.4-fold (0.16 log units) from the limit.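

In this assay compound 4 gives > 8000 nM, which is a limit of the assay and not a number. Cyclohexyl in place of 3,4-dimethylphenyl on the amine nitrogen brings an at least 7.6-fold higher number from compound 2 to compound 4 (0.88 log units; beyond the scatter), so in this pair, a non-aromatic ring on that nitrogen does not keep the inhibition that the aromatic ring gives. Compound 3, with no ring on that nitrogen, could not show this. Still open, as far as these compounds go, is whether any aromatic ring will do, for instance a plain phenyl or a pyridyl ring, or whether the two methyl groups of compound 2 also count.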